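A few compounds are considered here, and "the series" means these few. Any claim that something is new, unique, unknown or untested is made for them only; others in the source may bear on it.

Measured compounds:
compound 1 `CN(C)c1cccc2c(S(=O)(=O)N(CC(=O)NCc3ccccc3)Cc3ccc(C(=O)NO)cc3)cccc12` — 132 nM
compound 2 `CN(C)c1cccc2c(S(=O)(=O)N(CCCCCC(=O)NO)CC(=O)NCc3ccccc3)cccc12` — 46 nM

In an assay on Sf9 cells for inhibition of protein deacetylase HDAC6 (Homo sapiens), read by fluorescence, with a stated time of 90 min (on this read-out lower numbers stand for stronger inhibition and higher numbers for weaker inhibition), compound 1 gives 132 nM, the higher of the two numbers, and compound 2 gives 46 nM. Among the compounds with values here, the single measured step, a 2.9-fold lower number from compound 1 to compound 2 (0.46 log units; beyond the scatter), concerns the chain that carries the hydroxycarbamoyl group and leaves that group itself untouched; it therefore does not bear on the change to compound 3 `CN(C)c1cccc2c(S(=O)(=O)N(CC(=O)NCc3ccccc3)Cc3ccc(C(=O)Nc4ccccc4N)cc3)cccc12`. That change is 2-aminophenyl in place of hydroxy on an amide-type nitrogen. Within the data shown here, no measured pair covers a replacement of the hydroxy on this amide-type nitrogen, so the expectation rests on compound 1 alone and the range must be set wide. Starting from compound 1 with 132 nM, the step of a 19-fold higher number from compound 1 to compound 3 (1.28 log units; beyond the scatter) is expected, towards a higher number, and is expected to lie beyond the scatter. Compound 3 is thus estimated at 2500 nM, with a range from 300 nM to 20000 nM.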

Compound 3, half-maximal inhibitory concentration: > 10000 nM
Compound 3: no number, only a limit; the forecaster's own chance of this, stated with the estimate: 15%; at least 4.0-fold (0.60 log units) between middle value and limit.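

In this assay compound 3 reads > 10000 nM, which is a limit of the assay and not a number. Replacing hydroxy with 2-aminophenyl on the amide-type nitrogen gives an at least 75-fold higher number from compound 1 to compound 3 (1.87 log units; beyond the scatter), the only step shown that alters the hydroxycarbamoyl group itself, and this large step compares with the modest chain change of a 2.9-fold lower number from compound 1 to compound 2 (0.46 log units; beyond the scatter). The full size of the step at this position stays unfixed, since only a bound is available: the limit of > 10000 nM in this assay, at which 1 of the 3 values shown sits.

The compounds shown leave open whether a smaller group on this amide-type nitrogen, such as methoxy or a plain amine, would keep the number close to that of compound 1. On these data alone, it is also open whether (2-aminophenyl)carbamoyl would read the same at the end of the saturated chain of compound 2.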